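Halogen swap on the fused core: cytotoxicity notes

The source may report more compounds than this note shows. Statements on the series, on what has been measured and on what is new or still open speak of the compounds shown alone.

Measured so far:
compound 1 `N#Cc1cc2c(Oc3ccccc3OCCn3ccc(=O)[nH]c3=O)cc(F)cn2c1` – 40000 nM
compound 2 `N#Cc1cc2c(Oc3ccc(F)cc3OCCn3ccc(=O)[nH]c3=O)cc(F)cn2c1` – 50000 nM
compound 3 `N#Cc1ccc2c(Oc3ccc(F)cc3OCCn3ccc(=O)[nH]c3=O)cccc2c1` – > 100000 nM (a limit)

In an ADME assay on MT2 cells (Homo sapiens) for cytotoxicity, read by MTT assay (a lower number here means that less compound is tolerated, a higher number that more compound is tolerated), compound 1 gives 40000 nM, the lowest of the two numbers. Compound 2 sits nearest, and the step of a 1.3-fold higher number from compound 1 to compound 2 (0.10 log units; within the scatter) is within the scatter. For compound 3 only a limit is reported, (the limit of > 100000 nM in this assay, at which 1 of the 3 values shown sits).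

Compound 4 `N#Cc1cc2c(Oc3ccccc3OCCn3ccc(=O)[nH]c3=O)cc(Cl)cn2c1` differs from compound 1 by chloro in place of fluoro on an aromatic carbon. For the measured compounds named here, no measured step covers a chloro for fluoro exchange. Going by the values given here, the one measured step, a 1.3-fold higher number from compound 1 to compound 2 (0.10 log units; within the scatter), concerns a halogen added elsewhere and stays within the scatter, so no step beyond the scatter is expected in this assay from compound 1 to compound 4. The estimate for compound 4 is 40000 nM, between 20000 nM and 80000 nM, which would mean an expected step of no change at the digits printed from compound 1 to compound 4 (within the scatter).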

Compound 4, half-maximal cytotoxic concentration: 39000 nM
Compound 4: the middle estimate sits 1.0-fold (0.01 log units) above what was measured, and the stated range covers the measured number.
By their numbers in this assay, from the lowest: compounds 4, 1 and 2 (each within the scatter of the next). At a limit, above all of these: compound 3.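

At this position, on an aromatic carbon of a six-membered aromatic ring with 1 nitrogen, chloro in place of fluoro gives a 1.0-fold lower number from compound 1 to compound 4 (0.01 log units; within the scatter) in this assay. For the compounds shown here, the earlier step covered only a fluoro placed elsewhere, so this is the first reading of a halogen exchange at this carbon, and for this pair the choice of halogen does not separate the two compounds. Nothing in the data given accounts for this result.

As far as these compounds go, whether an amine or a carboxylic acid at this carbon would stay within the scatter of compound 1 remains open. Also open, from the compounds shown here alone, is whether chloro here would give the same result alongside the fluoro of compound 2.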